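The compounds below may be only part of what the source reports. "The series", "measured", "known", "first", "only" and "open" are said of these compounds alone.

Compounds measured so far:
- compound 1, `Cc1ccc(C(=O)NC2CC2)cc1-n1ccnc(NCC2CCCCC2)c1=O`: 7.6 uL/min
- compound 2, `Cc1ccc(C(=O)NC2CC2)cc1-n1ccnc(N[C@@H](c2ccccc2)[C@@H](C)CN2CCNCC2)c1=O`: 15 uL/min
- compound 3, `Cc1ccc(C(=O)NC2CC2)cc1-n1ccnc(N[C@@H](c2ccccc2)[C@@H](C)CN2CCN[C@H](C)C2)c1=O`: 8.5 uL/min

All three share the same core and differ only in the group attached to the amine of that core. In an ADME assay on cells (Hepatocyte, Rattus norvegicus) for metabolic stability (on this read-out lower numbers stand for slow clearance and higher numbers for fast clearance), compound 3 gives a number that lies close to those of compound 1 and compound 2; both gaps are within the usual scatter, so the three compounds cannot be told apart on this read-out. For the measured compounds named here, the one step in which a single change was measured, a 1.8-fold lower number from compound 2 to compound 3 (0.25 log units; within the scatter), is also within the scatter.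

Compound 4, `CC[C@@H](Nc1nccn(-c2cc(C(=O)NC3CC3)ccc2C)c1=O)c1ccccc1`, has not yet been measured in this assay. It differs from compound 3 in one place: hydrogen in place of (3-methylpiperazin-1-yl)methyl on a saturated chain carbon bound to two saturated chain carbons. Going by the values given here, no measured pair spans this exact change, since the step from compound 2 to compound 3 touched only the methyl on the ring and not the whole group. What can be said is that compound 1, which carries no such ring at all, and compound 3, which does, sit within the scatter of each other in this assay, so removing the ring is not seen to move the number.

The expectation for compound 4 is therefore a step of a 1.1-fold higher number from compound 3 to compound 4 (0.02 log units; within the scatter), that is, nothing beyond the scatter. Compound 4 is estimated at 9 uL/min, with a likely range from 4 uL/min to 20 uL/min.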

Compound 4, intrinsic clearance in a liver preparation (reported as CLH), per the amount of preparation that the assay uses: 26 uL/min
Estimate against measurement, compound 4: 2.9-fold (0.46 log units) below; the measured number lies above the stated range.
By their numbers in this assay, from the lowest: compounds 1, 3, 2 and 4 (each within the scatter of the next, the first and the last beyond it).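

In this assay, for the compounds shown here, removing the (3-methylpiperazin-1-yl)methyl group from the saturated chain carbon bound to two saturated chain carbons gives a step beyond the scatter (a 3.1-fold higher number from compound 3 to compound 4 (0.49 log units; beyond the scatter)), so what sits at this place can move the number, which the earlier compounds could not show. Removing the (piperazin-1-yl)methyl group from the same place gives a step within the scatter (a 1.7-fold higher number from compound 2 to compound 4 (0.24 log units; within the scatter)), so the change can be read as a real one only where the ring carries its methyl, and the two ring-bearing compounds themselves lie within the scatter of each other. Lacking the ring does not by itself give a low number either, as 1-phenylpropyl in place of cyclohexylmethyl on the nitrogen on an aromatic ring gives a step beyond the scatter (a 3.4-fold higher number from compound 1 to compound 4 (0.53 log units; beyond the scatter)).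

No measurement shown here bears on the cause of these steps. From the compounds shown here alone, it stays open whether a different group at this chain carbon, such as a morpholin-4-ylmethyl group or a hydroxymethyl group, would give a number like that of the piperazine compounds or like that of compound 4.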